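Selenium Methyl to Hydrogen: What to Expect for Compound 4

This account rests on a few compounds, and the source may have more. Where it says the series, first, only, none or still open, it means among the compounds named here.

Compound 1 `C[Se]c1nc(N)c2ccccc2n1` is the only one of the three measured compounds that gives a number in a functional assay on HT-29 cells (Homo sapiens) for cytotoxicity, read by MTT assay, with a stated time of 72 h; on this read-out lower numbers stand for stronger inhibition of growth and higher numbers for weaker inhibition of growth; there compound 1 gives 74800 nM. Compound 2 `CCCCCSc1nc(NCc2ccc([Se]C)cc2)c2ccccc2n1` reaches only a limit of the assay, and in this assay compound 2 gives > 100000 nM. Compound 3 `CSc1ccc(CNc2nc([Se]C)nc3ccccc23)cc1` likewise reaches only a limit, and in this assay compound 3 gives > 100000 nM. So compound 1 stands alone as the one measured value, while the other two values are limits (the limit of > 100000 nM in this assay, at which 2 of the 3 values shown sit). Among the compounds with values here, no pair of measured compounds differs in only one place, so no measured step is available to lean on.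

Compound 4 `Nc1nc([SeH])nc2ccccc12` differs from compound 1 by hydrogen in place of methyl on a selenium. The change is small: a methyl leaves a selenium whose other neighbour is an aromatic carbon, and a hydrogen enters in its place. Nothing among the three measured compounds shows what such a change does here, so no step beyond the usual scatter is expected in this assay, in either direction. The expected step from compound 1 to compound 4 is a 1.1-fold higher number from compound 1 to compound 4 (0.03 log units; within the scatter). For compound 4 the estimate in this assay is 80000 nM, with a range from 30000 nM to 200000 nM, and a real chance that the assay returns only a limit.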

Compound 4, concentration for total growth inhibition: > 100000 nM
Compound 4: a limit, no number; the forecaster's own chance of this, stated with the estimate: 35%; at least 1.2-fold (0.09 log units) between middle value and limit.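

Hydrogen in place of methyl on the selenium gives the first step that can be read at this position: in this assay the change gives an at least 1.3-fold higher number from compound 1 to compound 4 (0.12 log units; that floor lies within the scatter). Compound 4 gives > 100000 nM, which is a limit of the assay and not a number. The step is known only as a floor, so it does not show a loss of growth inhibition beyond the scatter, but it does show that the hydrogen compound does not join compound 1 in giving a number, and compound 1 remains the only compound shown that does: the limit of > 100000 nM in this assay, at which 3 of the 4 values shown sit.

As far as these compounds go, how far past the limit compound 4 truly lies stays open, so the real size of this step cannot be told, and it could still prove small or large. Also open is what a longer chain such as ethyl or butyl, or a group carrying an amine or a carboxylic acid, would do on this selenium, since the compounds shown that differ in this one place carry only methyl and hydrogen there.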